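A few compounds are considered here, and "the series" means these few. Any claim that something is new, unique, unknown or untested is made for them only; others in the source may bear on it.

In a functional assay on A549 cells (Homo sapiens) for antiproliferative activity, read by MTT assay, with a stated time of 72 h (a lower number here means a stronger inhibitor, a higher number a weaker inhibitor), three compounds that share a core and differ in one aromatic substituent have been measured. Compound 1 `O=C(N/N=C/c1ccc(Br)cc1)Nc1ccc(Oc2ccnc3[nH]ccc23)cc1` gives 640 nM, compound 2 `O=C(N/N=C/c1ccc(F)cc1)Nc1ccc(Oc2ccnc3[nH]ccc23)cc1` gives 1430 nM, and compound 3 `O=C(N/N=C/c1ccc([N+](=O)[O-])cc1)Nc1ccc(Oc2ccnc3[nH]ccc23)cc1` gives 2100 nM. Compound 3 stands close to its nearest neighbour, with a 1.5-fold higher number from compound 2 to compound 3 (0.17 log units; within the scatter), and furthest from the third, with a 3.3-fold higher number from compound 1 to compound 3 (0.52 log units; beyond the scatter). The remaining pair shows a 2.2-fold higher number from compound 1 to compound 2 (0.35 log units; beyond the scatter). Compound 4 `COc1ccc(/C=N/NC(=O)Nc2ccc(Oc3ccnc4[nH]ccc34)cc2)cc1` has methoxy in place of nitro on an aromatic carbon. For the measured compounds named here, no measured compound carries methoxy, so the direction is uncertain. Going by the values given here, the largest step so far is modest, namely a 3.3-fold higher number from compound 1 to compound 3 (0.52 log units; beyond the scatter), so only a small shift is expected in this assay, likely none beyond the scatter. The expected step is a 1.4-fold lower number from compound 3 to compound 4 (0.15 log units; within the scatter). The estimated value for compound 4 is 1500 nM, with an expected range of 600 nM to 3500 nM.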

Compound 4, half-maximal inhibitory concentration: 4300 nM
Compound 4: the middle estimate sits 2.9-fold (0.46 log units) below what was measured, and the stated range ends below it.
By their numbers in this assay, from the lowest: compound 1; then compounds 2 and 3 (each within the scatter of the next); then compound 4.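

In this assay methoxy gives the weakest number of the four groups at this position on the ring, beyond the scatter of each of the others (a 2.0-fold higher number from compound 3 to compound 4 (0.31 log units; beyond the scatter)) and (a 3.0-fold higher number from compound 2 to compound 4 (0.48 log units; beyond the scatter)) and (a 6.7-fold higher number from compound 1 to compound 4 (0.83 log units; beyond the scatter)). For the compounds shown here, the span across this one position is therefore wider than the earlier compounds showed, and bromo remains the strongest of the four. No measurement here explains this order of the groups.

From the compounds shown here alone, whether an amine, a carboxylic acid or a longer chain at this place would fall inside this span remains open. So does whether chloro would behave like bromo.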